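A few compounds are considered here, and "the series" means these few. Any claim that something is new, unique, unknown or untested is made for them only; others in the source may bear on it.

Compound 1, `CC1=C(C(=O)Nc2ccc(Br)cc2)C(c2ccc(Cl)cc2Cl)N=C(SCc2ccc(Cl)cc2)N1`, was tested in a functional assay on the whole organism (artery, strain albino) with Rattus norvegicus as the target, with a stated time of 600 min, at a dose of 10 mg/kg by the oral route (a lower number here means less inhibition, a higher number more inhibition at the dose given (going by the name of the read-out)), where compound 1 gives 30.3%. Compound 2, `CC1=C(C(=O)Nc2ccc(Br)cc2)C(c2ccc(Cl)cc2Cl)N=C(SCc2ccc(F)cc2)N1`, differs from compound 1 only by fluoro in place of chloro on an aromatic carbon. In this assay compound 2 gives 33.3%, so the step is a number 3 percentage points higher from compound 1 to compound 2 (within the scatter). Compound 3, `COc1ccc(C2N=C(SCc3ccc(Cl)cc3)NC(C)=C2C(=O)Nc2ccc(Br)cc2)cc1`, carries a different core; it differs from compound 1 by 4-methoxyphenyl in place of 2,4-dichlorophenyl on a saturated ring carbon. In this assay compound 3 gives 30.3%, and the step is no change at the digits printed from compound 1 to compound 3 (within the scatter), so the two cores give readings that lie within the scatter of each other.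

Compound 4, `COc1ccc(C2N=C(SCc3ccc(F)cc3)NC(C)=C2C(=O)Nc2ccc(Br)cc2)cc1`, has not yet been measured. It differs from compound 3 by fluoro in place of chloro on an aromatic carbon, the same change that separates compound 2 from compound 1, made at a place described in exactly the same words. Among the compounds shown this change appears in two pairs, and the one pair already measured gave a step of a number 3 percentage points higher from compound 1 to compound 2 (within the scatter), which does not rise above the usual scatter of repeated measurements.

The step that this estimate means is expected to be a number 1.7 percentage points higher from compound 3 to compound 4 (within the scatter), because the same change gave a number 3 percentage points higher from compound 1 to compound 2 (within the scatter) and that step sits within the scatter. Compound 4 is therefore expected to give about 32% in this assay. The expected range for compound 4 runs from 20% to 45%.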

Compound 4, a percentage reported as inhibition, in the whole organism at one dose (the size of the read-out at that dose, not a potency): 24.1%
Estimate against measurement, compound 4: 7.9 percentage points above, and the stated range covers the measured number.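

Read on the core of compound 3, fluoro in place of chloro gives a number 6.2 percentage points lower from compound 3 to compound 4 (within the scatter), and in this assay this step does not differ from the one seen for the same change on the core of compound 1: the same change on two cores in this assay, a number 3 percentage points higher (within the scatter) from compound 1 to compound 2 and a number 6.2 percentage points lower (within the scatter) from compound 3 to compound 4, 9.2 percentage points apart, within the scatter of two such steps. The other change, 4-methoxyphenyl in place of 2,4-dichlorophenyl, read with fluoro present, gives a number 9.2 percentage points lower from compound 2 to compound 4 (within the scatter), and it likewise does not differ from its earlier step: the same change on two cores in this assay, no change at the digits printed (within the scatter) from compound 1 to compound 3 and a number 9.2 percentage points lower (within the scatter) from compound 2 to compound 4, 9.2 percentage points apart, within the scatter of two such steps. So both changes carry from one core to the other without a difference these numbers can resolve, but this does not show that the steps are truly equal: every step lies within the scatter, and each change is seen in only two pairs, so a modest real effect could stay hidden.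

On these data alone, what an amine or a carboxylic acid in place of the chloro or fluoro would do to the reading remains open. Also open, as far as these compounds go, is whether any single change can give a step beyond the scatter in this assay, where only one dose and one time are reported.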